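The source may report more compounds than this note shows. Statements on the series, on what has been measured and on what is new or still open speak of the compounds shown alone.

Among the measured compounds shown here, compound 1 `O=Cc1cccc(C#Cc2ccc(CCC(=O)O)cc2)c1` stands at the top of the three numbers so far: in an in vitro functional assay on 1321-N1 cells for agonist activity at Free fatty acid receptor 1 (Homo sapiens), read by fluorescence (a lower number here means that less compound is needed, a higher number that more compound is needed for the effect), compound 1 gives 355 nM. Compound 3 `Cc1ccc(C#Cc2ccc(CCC(=O)O)cc2)cc1` gives 107 nM in this assay, and compound 2 `Cc1cccc(C#Cc2ccc(CCC(=O)O)cc2)c1C` gives 87.1 nM, both beyond the usual scatter below compound 1. For the measured compounds named here, no single-change step between two measured compounds is available, so the comparison rests on these three values alone.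

Compound 4 `O=C(O)CCc1ccc(C#Cc2cccc(C(F)(F)F)c2)cc1` differs from compound 1 in one place: trifluoromethyl in place of formyl on an aromatic carbon. Going by the values given here, the two methyl-bearing compounds, 2 and 3, both sit well below compound 1, which suggests that a group other than formyl at this position can be accompanied by a lower number, though no measured pair isolates the formyl itself. For compound 4 the step of a 3.0-fold lower number from compound 1 to compound 4 (0.47 log units; beyond the scatter) is therefore expected to point downward, beyond the scatter but with wide uncertainty. Compound 4 is estimated at 120 nM, with a range from 40 nM to 400 nM.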

Compound 4, half-maximal effective concentration: 89.1 nM
Estimate against measurement, compound 4: 1.3-fold (0.13 log units) above; low and high end bracket the measured number.
By their numbers in this assay, from the lowest: compounds 2, 4 and 3 (each within the scatter of the next); then compound 1.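

Replacing formyl with trifluoromethyl on this aromatic carbon gives a 4.0-fold lower number from compound 1 to compound 4 (0.60 log units; beyond the scatter) in this assay, the only single-change step among the compounds shown. It shows directly that the number responds to the group at this place. The earlier compounds shown here could only hint at this, and they differ from compound 1 in more than this one group. The change swaps a group of 2 heavy atoms with 1 hydrogen-bond acceptor for one of 4 heavy atoms with 0 hydrogen-bond acceptors, and the number still falls beyond the scatter. The compounds shown leave open whether a nitrile, an amine or a hydroxymethyl group on this carbon would read closer to compound 1 or to compound 4. No measurement given here accounts for the size or direction of this step.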